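The source may hold more compounds than are shown below. What is called first, only, known or untested is meant among the compounds shown, and "the series" means these compounds.

In a functional assay on the whole organism with Mus musculus as the target (a lower number here means that less compound is needed, a higher number that more compound is needed for the effect), compound 1 (`CNC(=O)/C(C)=C/c1cccc(C(F)(F)F)c1`) gives 75 mg/kg. Among the compounds with values here, compound 2 (`CN1C(=O)CCC1(O)c1cccc(C(F)(F)F)c1`) gives 93.8 mg/kg, and these two values lie within the usual scatter of each other, so compound 2 stands level with the only other measured compound. Compound 3 (`CCCCN1C(=O)CCC1(O)c1cccc(C(F)(F)F)c1`) is still unmeasured. It keeps the core of compound 2 and carries propyl in place of hydrogen on a saturated chain carbon bound to an amide-type nitrogen in a ring, which also reads as methyl to butyl (propyl in place of hydrogen on a saturated chain carbon bound to an amide-type nitrogen in a ring). Within the data shown here, no measured pair shows a change at this place, so the expectation rests on little. No step beyond the scatter is expected in this assay, with only a slight lean towards a lower dose. The estimated change is a 1.3-fold lower number from compound 2 to compound 3 (0.13 log units; within the scatter). For compound 3 the expected value is 70 mg/kg, with an estimated range from 30 mg/kg to 170 mg/kg.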

Compound 3, dose for half-maximal effect: > 200 mg/kg
Compound 3 gave a limit, no number (the forecaster's own chance of this, stated with the estimate: 15%); middle value at least 2.8-fold (0.45 log units) away from the limit.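

At this position, on a saturated chain carbon bound to an amide-type nitrogen in a ring, the series now has its first reading: in this assay, propyl in place of hydrogen, also read as methyl to butyl, gives an at least 2.1-fold higher number from compound 2 to compound 3 (0.32 log units; beyond the scatter). Compound 3 has > 200 mg/kg, which is a limit of the assay and not a number. The step therefore fixes only a minimum size, and its full size stays unknown: the limit of > 200 mg/kg in this assay, at which 1 of the 3 values shown sits.

On these data alone, with a single pair at this position, it remains open whether an ethyl chain in place of the methyl would stay level with compound 2 or already need a higher dose. A chain of similar length ending in an amine or a hydroxyl is also untested among the compounds shown, so chain length cannot be separated from the other features of butyl.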